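The compounds below may be only part of what the source reports. "The series", "measured", "known", "first", "only" and "open" are said of these compounds alone.

Compound 1 `O=C(O)CCc1c(-c2cccnc2)ccc2c1CCC(NS(=O)(=O)c1ccc(Cl)cc1)C2` gives 140 nM
Compound 2 `O=C(O)CCc1cc(-c2cccnc2)cc2c1CCC(NS(=O)(=O)c1ccc(Cl)cc1)C2` gives 670 nM

In a functional assay for inhibition, with Homo sapiens as the target (a higher number here means a weaker inhibitor, a lower number a stronger inhibitor), compound 2, at 670 nM, holds the higher of the two numbers, so it is the weaker inhibitor of the pair. The gap down to compound 1 lies beyond the usual scatter.

Compound 3 `O=C(O)CCc1cc(Cc2cccnc2)cc2c1CCC(NS(=O)(=O)c1ccc(Cl)cc1)C2` has not yet been measured. It departs from compound 2 by one change: (pyridin-3-yl)methyl in place of pyridin-3-yl on an aromatic carbon. Going by the values given here, no measured pair shows what such a change does, so the expectation is loose and no direction is favoured. No step beyond the scatter is expected in this assay. The estimated step is a 1.1-fold lower number from compound 2 to compound 3 (0.05 log units; within the scatter). For compound 3 the expected value is 600 nM, with an estimated range from 200 nM to 1800 nM.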

Compound 3, half-maximal inhibitory concentration: 7 nM
The estimate for compound 3 lay 86-fold (1.93 log units) above the measured number; the measured number lies below the stated range.
By their numbers in this assay, from the lowest: compound 3; then compound 1; then compound 2.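

In this assay, the change to (pyridin-3-yl)methyl gives a 96-fold lower number from compound 2 to compound 3 (1.98 log units; beyond the scatter), although the entering and leaving groups have the same aromatic ring, hydrogen-bond counts and lack of net charge. Compound 1 and compound 2 both carry pyridin-3-yl directly on the aromatic carbon, so only compound 3 shows that this position, meta to the 2-carboxyethyl group and para to a fused ring, responds strongly to a methylene link before the pyridine. Nothing at hand explains the size of this step.

The compounds shown leave open whether a longer chain, such as a 2-(pyridin-3-yl)ethyl group, or an ether oxygen or carbonyl link would match the methylene link. They also leave open whether a benzyl group would do the same, and whether the change would carry over to the aromatic carbon bearing pyridin-3-yl in compound 1.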